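Removing One Methoxy Group from a Melanoma Growth Inhibitor

This account rests on a few compounds, and the source may have more. Where it says the series, first, only, none or still open, it means among the compounds named here.

Among three compounds tested in a functional assay on SK-MEL-28 cells (Homo sapiens) for inhibition, read by sulforhodamine B assay, with a stated time of 48 h (on this read-out lower numbers stand for stronger inhibition of growth and higher numbers for weaker inhibition of growth), compound 2 `COc1ccc(-c2[nH]c3ccc(OC)cc3c2/C=C(\C#N)S(=O)(=O)c2ccccc2)cc1` gives the lowest number, 787 nM. Compound 3 `COc1ccc(-c2[nH]c3ccc(OC)cc3c2C=C(C#N)C#N)cc1` gives 1700 nM, a gap beyond the usual scatter, and compound 1 `N#C/C(=C\c1c(-c2ccccc2)[nH]c2ccccc12)C(=O)c1ccccc1` gives 12000 nM, far weaker than compound 2. Compound 4 `COc1ccc(-c2[nH]c3ccccc3c2/C=C(\C#N)S(=O)(=O)c2ccccc2)cc1` has not yet been measured. It differs from compound 2 in one place: hydrogen in place of methoxy on an aromatic carbon. Within the data shown here, no measured pair shows this exact change, so its effect is uncertain. On these data alone, both methoxy-bearing compounds do far better than compound 1, but they differ from it in several places at once, so what this one methoxy contributes is unknown. The expectation is a small weakening, a 1.7-fold higher number from compound 2 to compound 4 (0.22 log units; within the scatter), near the edge of the scatter. Compound 4 is therefore estimated at 1300 nM, with a likely range from 500 nM to 3500 nM.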

Compound 4, concentration for 50% growth inhibition: 1800 nM
Estimate against measurement, compound 4: 1.4-fold (0.14 log units) below, and the stated range covers the measured number.
By their numbers in this assay, from the lowest: compound 2; then compounds 3 and 4 (each within the scatter of the next); then compound 1.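

Taking the methoxy group off this aromatic carbon weakens growth inhibition modestly but measurably (a 2.3-fold higher number from compound 2 to compound 4 (0.36 log units; beyond the scatter)). Among these compounds, this is the first direct reading of what this methoxy contributes, as the earlier compounds differed from one another in several places at once, and compound 4 shows that activity is reduced rather than lost without it. No measurement here explains the weakening.

On these data alone, whether a hydroxyl group, an ethoxy group or a fluorine atom would do better at this position remains open. So does whether the same change would have a similar effect on compound 3.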